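This account rests on a few compounds, and the source may have more. Where it says the series, first, only, none or still open, it means among the compounds named here.

Measured compounds:

Compound 1, `COc1ccc(N/C=C\C(=O)c2nc(-c3ccc(C(F)(F)F)cc3)n3ccccc23)cc1OC`. In a functional assay on BT-474 cells (Homo sapiens) for cytotoxicity, read by MTT assay, with a stated time of 48 h (a higher number here means a weaker inhibitor, a lower number a stronger inhibitor), compound 1 gives > 30000 nM, which is a limit of the assay and not a number.
Compound 2, `O=C(/C=C\Nc1ccc2[nH]ccc2c1)c1nc(-c2ccc(C(F)(F)F)cc2)n2ccccc12`. In this assay compound 2 gives 5190 nM.
Compound 3, `O=C(/C=C\Nc1ccc(Cl)cc1)c1nc(-c2ccc(C(F)(F)F)cc2)n2ccccc12`. In this assay compound 3 gives 3820 nM.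

Compound 1 therefore stands only at the limit of > 30000 nM in this assay, at which 1 of the 3 values shown sits; its own number is not known, and only a lower edge is. The two measured steps away from it, an at least 5.7-fold lower number from compound 1 to compound 2 (0.76 log units; beyond the scatter) and an at least 7.8-fold lower number from compound 1 to compound 3 (0.89 log units; beyond the scatter), both replace the group on the amine nitrogen and leave the rest of the shared core untouched. The step from compound 2 to compound 3, a 1.4-fold lower number from compound 2 to compound 3 (0.13 log units; within the scatter), also concerns that nitrogen.

Compound 4, `COc1ccc(N/C=C\C(=O)c2nc(-c3ccc(F)cc3)n3ccccc23)cc1OC`, differs from compound 1 elsewhere: fluoro in place of trifluoromethyl on an aromatic carbon. Among the compounds with values here, none of the measured steps touches this part of the molecule, so they give no guide to the direction or size of the change in this assay, and the starting point is itself a limit. Without a measured step at this position, the expected step is a number no higher from compound 1 to compound 4 (the limit leaves the size open), read against the limit of compound 1. Compound 4 is expected to give about 30000 nM, within 8000 nM to 100000 nM.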

Compound 4, half-maximal inhibitory concentration: > 30000 nM
Compound 4: no number, only a limit (the forecaster's own chance of this, stated with the estimate: 55%); the middle value lies on the limit itself.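

Compound 1 and compound 4 each give a limit of the assay and not a number, so the step between them cannot be read: the limit of > 30000 nM in this assay, at which 2 of the 4 values shown sit.

The compounds shown leave open whether fluoro in place of trifluoromethyl changes the number in this assay at all, and in which direction.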